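Turning One Double Bond From E to Z

This account rests on a few compounds, and the source may have more. Where it says the series, first, only, none or still open, it means among the compounds named here.

Measured in an ADME assay on HCT-116 cells (Homo sapiens) for antiproliferative activity; a higher number here means a weaker inhibitor, a lower number a stronger inhibitor
Compound 1 `COc1ccc(C(C)=O)cc1COc1cccc(C)c1` gives 24000 nM
Compound 2 `COc1ccc(C(N)=O)cc1COc1ccc(Cl)c(C)c1` gives > 50000 nM (a limit of the assay, not a number)
Compound 3 `COc1ccc(C(N)=O)cc1/C=C/c1ccc(Cl)cc1` gives 7100 nM

Among the two values given as true numbers, compound 3 has the lower one, which makes it the stronger inhibitor of that pair. Compound 1 is its nearest neighbour, and the gap between them lies beyond the scatter of repeated measurements.

The next compound to be tested is compound 4 `COc1ccc(C(N)=O)cc1/C=C\c1ccc(Cl)cc1`. The change is small to draw: the two compounds have the same atoms and bonds and differ only in configuration as drawn: 1 of 1 stereo elements differ; a double bond is drawn E in compound 3 and Z in compound 4. In words, a double bond is drawn E in compound 3 and Z in compound 4.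

Among the compounds with values here, no measured pair in this set shows what such a switch does, so the expectation is loose. No step beyond the scatter is expected, in either direction, and the estimated change is a 1.4-fold lower number from compound 3 to compound 4 (0.15 log units; within the scatter) in this assay. For compound 4 the expected value is 5000 nM, with an estimated range from 800 nM to 40000 nM.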

Compound 4, half-maximal inhibitory concentration: 29000 nM
For compound 4 the middle estimate is 5.8-fold (0.76 log units) below the measured one; the measured number falls inside the stated range.
By their numbers in this assay, from the lowest: compound 3; then compounds 1 and 4 (each within the scatter of the next). At a limit, above all of these: compound 2.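

In this assay, changing the double bond from E to Z gives a 4.1-fold higher number from compound 3 to compound 4 (0.61 log units; beyond the scatter), so compound 3, with the E form, is the stronger inhibitor of this pair. Within the data shown here, this is the first comparison in the set in which only one thing changes, and it shows that the configuration at this double bond can move the result beyond the usual scatter, even with no atom added or removed. The step can be tied to the configuration alone because nothing else separates the two compounds: the fact that compounds 3 and 4 differ only in the configuration as drawn

The compounds shown leave open whether E would still beat Z if the amide of compounds 3 and 4 gave way to a carboxylic acid. They also leave open how a triple bond in place of the double bond would compare with either form.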